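A Shorter Chain on the Aromatic Nitrogen

The compounds below may be only part of what the source reports. "The series", "measured", "known", "first", "only" and "open" are said of these compounds alone.

Of the compounds shown here, three sharing one core have been measured in a functional assay on SK-MEL-28 cells (Homo sapiens) for cytotoxicity, read by MTT assay, with a stated time of 3 days; on this read-out higher numbers stand for weaker inhibition and lower numbers for stronger inhibition. Compound 1 `N#Cc1c(Cl)nc(SCc2nc3ccccc3[nH]2)nc1-c1ccccc1` gives 3.28 nM, compound 2 `N#Cc1c(Nc2ccccn2)nc(SCc2nc3ccccc3[nH]2)nc1-c1ccccc1` gives 8.9 nM, and compound 3 `N#Cc1c(NNC(N)=S)nc(SCc2nc3ccccc3[nH]2)nc1-c1ccccc1` gives 3.2 nM. Compound 3 therefore stands level with compound 1, as a 1.0-fold lower number from compound 1 to compound 3 (0.01 log units; within the scatter) shows, and clearly under compound 2, as a 2.8-fold lower number from compound 2 to compound 3 (0.44 log units; beyond the scatter) shows.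

Compound 4 `N#Cc1c(NC(N)=S)nc(SCc2nc3ccccc3[nH]2)nc1-c1ccccc1` has yet to be measured. It departs from compound 3 in a single place, on a nitrogen on an aromatic ring: a group of 3 heavy atoms (1 carbon, 1 nitrogen, 1 sulfur; no ring) in place of a group of 4 heavy atoms (1 carbon, 2 nitrogen, 1 sulfur; no ring), on a nitrogen on an aromatic ring. Within the data shown here, the closest precedent is a 2.8-fold lower number from compound 2 to compound 3 (0.44 log units; beyond the scatter), the only measured step that exchanges a group on this same nitrogen, although it involves a much larger change that removes a ring. The other two steps replace the chlorine on an aromatic carbon: a 2.7-fold higher number from compound 1 to compound 2 (0.43 log units; beyond the scatter) and a 1.0-fold lower number from compound 1 to compound 3 (0.01 log units; within the scatter). Among the measured compounds shown here, none of these changes moved the number by more than a modest amount, and no measured step shows the effect of so small a trim. A small shift is therefore expected, most likely within the scatter and, if anything, towards a higher number. The expected change is a 1.4-fold higher number from compound 3 to compound 4 (0.15 log units; within the scatter). Compound 4 is estimated at 4.5 nM, with an expected range from 1.8 nM to 11 nM.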

Compound 4, half-maximal inhibitory concentration: 4.8 nM
Estimate against measurement, compound 4: 1.1-fold (0.03 log units) below; the range from low to high includes it.
By their numbers in this assay, from the lowest: compounds 3, 1, 4 and 2 (each within the scatter of the next, the first and the last beyond it).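

Among these compounds, on the nitrogen on an aromatic ring, going from the group of 4 heavy atoms to the group of 3 heavy atoms gives, in this assay, a 1.5-fold higher number from compound 3 to compound 4 (0.18 log units; within the scatter), so a trim this small leaves no readable change at this place, which no earlier step could show. Compound 4 also fails to separate from the other two compounds, with a 1.9-fold lower number from compound 2 to compound 4 (0.27 log units; within the scatter) on the same nitrogen and a 1.5-fold higher number from compound 1 to compound 4 (0.17 log units; within the scatter) on the aromatic carbon that carries the chlorine, whereas the step from compound 2 to compound 3 was printed beyond the scatter; the larger group on compound 2 is thus set apart from compound 3 but not from compound 4. Nothing measured here bears on why these numbers fall as they do.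

The compounds shown leave open how a plain amine, a urea with oxygen in place of the sulfur, or a longer chain on this nitrogen would read in this assay. They also leave open whether these small differences would hold on any other cell line.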